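This account rests on a few compounds, and the source may have more. Where it says the series, first, only, none or still open, it means among the compounds named here.

Work in an in vitro ADME assay on microsomes from liver (Mus musculus) for metabolic stability, read by LC-MS, tested at 1 uM (a higher number here means that the compound lasts longer, a lower number that the compound disappears faster), is summarised here. In this assay compound 1 `CCC(CC)C(=O)N/C(=N/c1nccn1C(C)C)Nc1ccc(Cl)c(Cl)c1` gives > 1 h, which is a limit of the assay and not a number. Compound 2 `CC(C)n1ccnc1/N=C(/NC(=O)C(C)(C)C)Nc1ccc(Cl)c(Cl)c1` gives > 1 h in this assay, again a limit rather than a number. The step that the two limits leave unreadable from compound 1 to compound 2 therefore cannot be read, and the limit of > 1 h in this assay, at which 2 of the 2 values shown sit, is all the measured pair shows. Compound 2 thus stands at the limit, with no number to place it against compound 1.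

Compound 3 `CC(C)n1ccnc1/N=C(/NC(=O)OC(C)(C)C)Nc1ccc(Cl)c(Cl)c1` differs from compound 2 by tert-butoxy in place of tert-butyl on a carbonyl carbon; cut one bond further out this reads (tert-butyl)carbonyl to tert-butoxycarbonyl. Among the compounds with values here, no measured step bears on this change: the only measured pair, compound 1 to compound 2, alters the alkyl on the carbonyl carbon and is itself unreadable. The expectation for compound 3 in this assay rests only on the two limits, with the step that the limit leaves unreadable from compound 2 to compound 3 expected to stay within the scatter. Compound 3 is estimated at 1.5 h, with a range from 0.7 h to 3 h, and is most likely again reported only as a limit.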

Compound 3, half-life: > 1 h
Compound 3 was reported as a limit; the forecaster's own chance of this, stated with the estimate: 70%; the middle value lies beyond the limit too.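

In this assay compound 3 gives > 1 h, a limit of the assay and not a number. No step among compound 1, compound 2 and compound 3 can be read, and the series shows only this: the limit of > 1 h in this assay, at which 3 of the 3 values shown sit.

From the compounds shown here alone, whether pentan-3-yl, tert-butyl and tert-butoxy on the carbonyl carbon differ at all in half-life remains open.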